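The source may hold more compounds than are shown below. What is called first, only, known or untested is meant among the compounds shown, and "the series" means these compounds.

Working notes on a series of amide-linked inhibitors assessed in an assay on isolated protein for inhibition of tyrosine-protein kinase receptor UFO (Homo sapiens), read by ELISA; on this read-out lower numbers stand for stronger inhibition and higher numbers for weaker inhibition.

Compound 1 `Cn1cc(-c2ccc(NC(=O)c3cn(CC4CCOCC4)cc(-c4ccc(F)cc4F)c3=O)cc2)c2c(N)ncnc21` gives 0.8 nM in this assay. Compound 2 `Cn1cc(-c2ccc(NC(=O)c3cn(CC4CCCCC4)cc(-c4ccc(F)cc4)c3=O)cc2)c2c(N)ncnc21` gives 2.3 nM. Compound 3 `Cn1cc(-c2ccc(NC(=O)c3cn(CC4CCOCC4)cc(-c4ccc(F)cc4)c3=O)c(Cl)c2)c2c(N)ncnc21` gives 3.7 nM. Among these three numbers compound 2 stands second highest. Its nearest neighbour is compound 3, and the gap between the two lies within the scatter, so no order between compound 2 and compound 3 can be read. Compound 1 lies furthest from compound 2, with a lower number beyond the scatter.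

Compound 4 `CC(C)n1cc(C(=O)Nc2ccc(-c3cn(C)c4ncnc(N)c34)cc2)c(=O)c(-c2ccc(F)cc2)c1` has not yet been measured. It differs from compound 2 in one place:

isopropyl in place of cyclohexylmethyl on an aromatic nitrogen

Among the measured compounds shown here, no pair of measured compounds differs in this group alone, so the effect of the substituent on that aromatic nitrogen is untested here and the size of the step cannot be taken from measured pairs. The step from compound 2 to compound 4 is expected to be a modest rise in number, a 2.2-fold higher number from compound 2 to compound 4 (0.34 log units; beyond the scatter), at the edge of the scatter rather than clearly beyond it. Compound 4 is therefore expected to give about 5 nM in this assay, with a range from 1.5 nM to 15 nM.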

Compound 4, half-maximal inhibitory concentration: 0.4 nM
Compound 4: the middle estimate sits 13-fold (1.10 log units) above what was measured, outside the stated range (below it).
By their numbers in this assay, from the lowest: compounds 4 and 1 (each within the scatter of the next); then compounds 2 and 3 (each within the scatter of the next).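

In this assay, the group on this aromatic nitrogen now has a measured step, a 5.8-fold lower number from compound 2 to compound 4 (0.76 log units; beyond the scatter), on replacing cyclohexylmethyl with isopropyl while the rest of compound 2 stays unchanged. For this pair, the six-membered carbon ring and the larger group of 7 heavy atoms are therefore not needed for a low number: isopropyl, with 3 heavy atoms and no ring, gives the lower number of the two, and neither group carries a hydrogen-bond donor, an acceptor or a net charge. No measurement shown accounts for the size or direction of this step.

This single pair changes group size and the presence of a ring together, so it cannot separate the two or show whether the number keeps falling with smaller groups such as ethyl or methyl, or how a cyclopropyl ring would compare with isopropyl. Among the compounds shown here, also open is how this position responds to a hydroxyethyl chain or a dimethylaminoethyl chain, and whether the step from cyclohexylmethyl to isopropyl holds with a different aryl group on the core, such as the one in compound 1.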